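Amide nitrogen substituents in a catechol diether series

This account rests on a few compounds, and the source may have more. Where it says the series, first, only, none or still open, it means among the compounds named here.

Measured compounds:
compound 1 `COc1ccc(C(=O)Nc2c(C)cccc2Cl)cc1OC1CCCC1`, 100 nM
compound 2 `COc1ccc(C(=O)Nc2nccs2)cc1OC1CCCC1`, 6500 nM
compound 3 `COc1ccc(C(=O)NC2(C)C=C(C)ON2)cc1OC1CCCC1`, 450 nM

In an assay on isolated protein for inhibition of phosphodiesterase 4A (Sus scrofa) (a higher number here means a weaker inhibitor, a lower number a stronger inhibitor), compound 3 stands second highest of the three, with compound 1 nearest at a 4.5-fold higher number from compound 1 to compound 3 (0.65 log units; beyond the scatter) and compound 2 furthest at a 14-fold lower number from compound 2 to compound 3 (1.16 log units; beyond the scatter). Compound 4 `COc1ccc(C(=O)Nc2c(C)nsc2Br)cc1OC1CCCC1` differs from compound 3 in one place: a group of 7 heavy atoms (4 carbon, 1 nitrogen, 1 sulfur, 1 bromine; one five-membered aromatic ring with 2 hetero atoms) in place of a group of 7 heavy atoms (5 carbon, 1 nitrogen, 1 oxygen; one five-membered non-aromatic ring with 2 hetero atoms), on an amide-type nitrogen. Among the compounds with values here, two steps bear on this. An aromatic ring with two hetero atoms entered once before, a 65-fold higher number from compound 1 to compound 2 (1.81 log units; beyond the scatter), and left again, a 14-fold lower number from compound 2 to compound 3 (1.16 log units; beyond the scatter), both large; but that ring carried no substituents, whereas the entering group, like the 2-chloro-6-methylphenyl of compound 1, carries a methyl and a halogen. A modest step down is therefore expected, a 3.0-fold lower number from compound 3 to compound 4 (0.48 log units; beyond the scatter). Compound 4 is estimated at 150 nM, range 30 nM to 800 nM.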

Compound 4, half-maximal inhibitory concentration: 500 nM
Beside the measured number, compound 4's estimate is 3.3-fold (0.52 log units) below it; measured number inside the range.
By their numbers in this assay, from the lowest: compound 1; then compounds 3 and 4 (each within the scatter of the next); then compound 2.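

In this assay, the 5-bromo-3-methyl-1,2-thiazol-4-yl group on the amide-type nitrogen reads the same as the group of compound 3 (a 1.1-fold higher number from compound 3 to compound 4 (0.05 log units; within the scatter)), so an aromatic ring with two hetero atoms is compatible with activity at this position. The two thiazole-type groups differ widely (a 13-fold lower number from compound 2 to compound 4 (1.11 log units; beyond the scatter)), while 2-chloro-6-methylphenyl still gives the lower number (a 5.0-fold higher number from compound 1 to compound 4 (0.70 log units; beyond the scatter)). Nothing available explains these differences. Open, going by these compounds, is whether the bromine or the methyl accounts for the step from compound 2, and how a cyclohexyl group or an unsubstituted phenyl on this nitrogen would read.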